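Methoxy in Place of Methyl: Expecting Compound 3

This account rests on a few compounds, and the source may have more. Where it says the series, first, only, none or still open, it means among the compounds named here.

Measured compounds:
compound 1, `Cc1ccc(S(=O)(=O)c2nc3ccccc3nc2Nc2cccc(N)c2)cc1`: 2000 nM
compound 2, `Cc1ccc(S(=O)(=O)c2nc3ccccc3nc2Nc2ccc(C(F)(F)F)cc2)cc1`: 2540 nM

In a functional assay on PC-3 cells (Homo sapiens) for cytotoxicity, read by MTT assay, with a stated time of 72 h (on this read-out lower numbers stand for stronger inhibition and higher numbers for weaker inhibition), compound 1 gives 2000 nM, the lower of the two numbers available. Compound 2 gives 2540 nM in this assay, and the step of a 1.3-fold higher number from compound 1 to compound 2 (0.10 log units; within the scatter) lies within the scatter, so the two compounds cannot be ordered on these data.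

Compound 3, `COc1ccc(S(=O)(=O)c2nc3ccccc3nc2Nc2cccc(N)c2)cc1`, differs from compound 1 by methoxy in place of methyl on an aromatic carbon. Within the data shown here, no measured step touches that part of the shared core. Among the measured compounds shown here, the only measured step, a 1.3-fold higher number from compound 1 to compound 2 (0.10 log units; within the scatter), concerns a different position and stayed within the scatter, so it offers no direction for the present change. Given only that, the step of no change at the digits printed from compound 1 to compound 3 (within the scatter) is expected to remain within the scatter. Compound 3 is estimated at 2000 nM in this assay, with a range from 1000 nM to 4000 nM.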

Compound 3, half-maximal inhibitory concentration: 8600 nM
Beside the measured number, compound 3's estimate is 4.3-fold (0.63 log units) below it; measured number outside the range, above it.
By their numbers in this assay, from the lowest: compounds 1 and 2 (each within the scatter of the next); then compound 3.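

Among these compounds, the position carrying the 4-methylphenyl group, which no earlier step had touched, proves sensitive to change: in this assay the move to 4-methoxyphenyl gives a 4.3-fold higher number from compound 1 to compound 3 (0.63 log units; beyond the scatter) and so yields the first pair of compounds here that the data can order. Methoxy in place of methyl on an aromatic carbon, para to a large group, is thus enough to shift the number towards weaker inhibition. No measured evidence is available to explain this shift.

The compounds shown leave open whether a hydroxyl, an ethoxy or a chlorine at this place would give a number near that of compound 1 or near that of compound 3. They also leave open whether the same change would carry over to compound 2, which bears 4-(trifluoromethyl)phenyl instead of 3-aminophenyl.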